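Compound 2 to compound 3: adding an octylamino chain

The compounds below may be only part of what the source reports. "The series", "measured", "known", "first", "only" and "open" are said of these compounds alone.

Results in a functional assay on NCI-H460 cells (Homo sapiens) for cytotoxicity, read by MTT assay, with a stated time of 72 h (on this read-out lower numbers stand for stronger inhibition and higher numbers for weaker inhibition), so far:
- Compound 1 `CCCCNC1=CC(=O)C(C[C@]2(C)[C@@H](C)CC[C@]3(C)C(C)=CCC[C@@H]23)=CC1=O` gives > 100000 nM as a limit, not a number.
- Compound 2 `CC1=CCC[C@H]2[C@](C)(CC3=CC(=O)C=CC3=O)[C@@H](C)CC[C@]12C` gives 24000 nM as a measured number.

Among the measured compounds shown here, compound 2 therefore holds the only exact number so far, and the one other result is a limit. Compound 3 `CCCCCCCCNC1=CC(=O)C(C[C@]2(C)[C@@H](C)CC[C@]3(C)C(C)=CCC[C@@H]23)=CC1=O` differs from compound 2 by octylamino in place of hydrogen on a double-bonded ring carbon, with octylamino in place of hydrogen on a double-bonded ring carbon. For the measured compounds named here, the one measured step that bears on this is an at least 4.1-fold lower number from compound 1 to compound 2 (0.61 log units; beyond the scatter), with hydrogen in place of butylamino on a double-bonded ring carbon. Read in reverse, that step beyond the scatter suggests that adding an alkylamino chain raises the number, though no octylamino chain has been measured. The estimated change is a 2.5-fold higher number from compound 2 to compound 3 (0.40 log units; beyond the scatter), towards weaker inhibition. For compound 3 the expected value is 60000 nM, with an estimated range from 15000 nM to 150000 nM in this assay.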

Compound 3, half-maximal inhibitory concentration: > 100000 nM
Compound 3 ended at the assay's limit (the forecaster's own chance of this, stated with the estimate: 40%); middle value at least 1.6-fold (0.22 log units) from the limit.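

In this assay, placing octylamino on this double-bonded ring carbon gives an at least 4.1-fold higher number from compound 2 to compound 3 (0.61 log units; beyond the scatter) towards weaker inhibition. Until now only butylamino had shown such a loss, so the loss is no longer tied to a single chain: with both alkylamino chains shown, the compound without a chain, compound 2, has the lower number. Compound 1 and compound 3 each give a limit rather than a number, so the step between them cannot be read and the two chain lengths cannot be ranked: the limit of > 100000 nM in this assay, at which 2 of the 3 values shown sit.

On these data alone, whether a much shorter group on this carbon, such as methylamino or a plain amine, would give a number below the limit remains open. So does the effect of a chain ending in a carboxylic acid.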